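Oxadiazole series: removing one chloro from compound 2

The compounds below may be only part of what the source reports. "The series", "measured", "known", "first", "only" and "open" are said of these compounds alone.

Compound 2 `Cc1nc(-c2cccnc2)sc1-c1nnc(-c2cccc(Cl)c2Cl)o1` carries a 2,3-dichlorophenyl on the shared core. In an ADME assay on HCT-116 cells (Homo sapiens) for cytotoxicity, read by MTT assay (on this read-out lower numbers stand for higher toxicity in this test and higher numbers for lower toxicity in this test), compound 2 gives only a limit of the assay, > 100 ug/mL. Compound 1 `Cc1nc(-c2cccnc2)sc1-c1nnc(-c2ccncc2)o1`, which carries pyridin-4-yl in that place, likewise reaches only a limit in this assay, > 100 ug/mL. The step that the two limits leave unreadable from compound 1 to compound 2 therefore cannot be read, because both values sit at the limit of > 100 ug/mL in this assay, at which 2 of the 2 values shown sit. Compound 3 `Cc1nc(-c2cccnc2)sc1-c1nnc(-c2ccccc2Cl)o1` differs from compound 2 by hydrogen in place of chloro on an aromatic carbon. Going by the values given here, no measured step bears on this change: the single step is unreadable, and nothing tells how a chloro on this phenyl moves the read-out. With compound 2 already at the limit, no step beyond the scatter in this assay is expected in either direction, and compound 3 is expected to return a limit as well. Compound 3 is estimated at 150 ug/mL, in the range 70 ug/mL to 400 ug/mL, which means an expected step that the limit leaves unreadable from compound 2 to compound 3.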

Compound 3, half-maximal cytotoxic concentration: > 100 ug/mL
Compound 3: a limit, no number; the forecaster's own chance of this, stated with the estimate: 80%; the middle value is on the limit's open side.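

No new step can be read among compound 1, compound 2 and compound 3 in this assay, because all three values are limits and not numbers: the limit of > 100 ug/mL in this assay, at which 3 of the 3 values shown sit.

The compounds shown leave open whether any group in this place on the shared core gives a readable number in this assay.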